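Extending the Piperazine Substituent from Methyl to Ethyl

The source may report more compounds than this note shows. Statements on the series, on what has been measured and on what is new or still open speak of the compounds shown alone.

Of the compounds shown here, three sharing one core have been measured in a functional assay on K562 cells (Homo sapiens) for inhibition, read by MTT assay, with a stated time of 48 h; on this read-out lower numbers stand for stronger inhibition and higher numbers for weaker inhibition. Compound 1 `Cc1ccc(NC(=O)c2cccc(C(F)(F)F)c2)cc1-n1cc(-c2cccnc2)cn1` gives 270 nM, compound 2 `Cc1ccc(NC(=O)c2ccc(F)cc2)cc1-n1cc(-c2cccnc2)cn1` gives 12500 nM, and compound 3 `Cc1ccc(NC(=O)c2ccc(CN3CCN(C)CC3)cc2)cc1-n1cc(-c2cccnc2)cn1` gives 1670 nM. The step of a 46-fold higher number from compound 1 to compound 2 (1.67 log units; beyond the scatter) is large, whereas a 7.5-fold lower number from compound 2 to compound 3 (0.87 log units; beyond the scatter) is modest. Compound 3 thus holds the second highest of the three numbers, separated beyond the scatter from both of the others.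

Compound 4 `CCN1CCN(Cc2ccc(C(=O)Nc3ccc(C)c(-n4cc(-c5cccnc5)cn4)c3)cc2)CC1` has not yet been measured. It differs from compound 3 by methyl in place of hydrogen on a saturated chain carbon bound to an amine nitrogen in a ring. Neither measured step touches this part of the molecule; both concern the aromatic ring on the carbonyl carbon. No measured comparison therefore bears directly on the change, and with so small an addition the expected step in this assay is none beyond the scatter. Compound 4 is expected to give about 1500 nM, between 600 nM and 4000 nM, so that the step of a 1.1-fold lower number from compound 3 to compound 4 (0.05 log units; within the scatter) is estimated to be small.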

Compound 4, half-maximal inhibitory concentration: 2330 nM
Beside the measured number, compound 4's estimate is 1.6-fold (0.19 log units) below it; measured number inside the range.
By their numbers in this assay, from the lowest: compound 1; then compounds 3 and 4 (each within the scatter of the next); then compound 2.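

In this assay, within the data shown here, 4-ethylpiperazin-1-yl in place of 4-methylpiperazin-1-yl gives a 1.4-fold higher number from compound 3 to compound 4 (0.14 log units; within the scatter), so this position accepts the added methyl with no step that can be told from the scatter. The fall in the number from the fluoro compound also holds with the ethyl group, as the exchange shows a 5.4-fold lower number from compound 2 to compound 4 (0.73 log units; beyond the scatter). No measurement on hand gives a reason for either result.

The compounds shown leave open whether a longer chain such as propyl, or a 2-hydroxyethyl group, would also stay within the scatter of the methyl and ethyl groups at this place. They also leave open whether morpholin-4-yl in place of 4-ethylpiperazin-1-yl would keep the number beyond the scatter of the fluoro compound.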